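Configuration Change in a Mildly Cytotoxic Series

This account rests on a few compounds, and the source may have more. Where it says the series, first, only, none or still open, it means among the compounds named here.

Compound 1 (`Nc1nc2c(ncn2/C=C2\C[C@@H]2[C@H](O)CO)c(=O)[nH]1`) gives 67000 nM
Compound 2 (`Nc1ncnc2c1ncn2/C=C1/C[C@H]1[C@H](O)CO`) gives 93500 nM
Compound 3 (`Nc1ncnc2c1ncn2/C=C1\C[C@H]1[C@@H](O)CO`) gives 73000 nM

In an ADME assay on Akata cells (Homo sapiens) for cytotoxicity (on this read-out lower numbers stand for higher toxicity in this test and higher numbers for lower toxicity in this test), compound 1 sits within the usual scatter of both compound 2 and compound 3, so these three cannot be ranked. Compound 4 (`Nc1nc2c(ncn2/C=C2\C[C@H]2[C@@H](O)CO)c(=O)[nH]1`) differs from compound 1 only in configuration as drawn (the two compounds have the same atoms and bonds and differ only in configuration as drawn: 2 of 3 stereo elements differ; a stereocentre at a saturated ring carbon is drawn S in compound 1 and R in compound 4; a stereocentre at a saturated chain carbon is drawn S in compound 1 and R in compound 4). Within the data shown here, the one measured guide (a 1.3-fold lower number from compound 2 to compound 3 (0.11 log units; within the scatter)) is also a change of configuration alone (the fact that compounds 2 and 3 differ only in the configuration as drawn) and stays within the scatter, although it involves a double bond and a chain carbon, not a ring carbon. No step beyond the scatter is therefore expected in this assay for this pair. The expected change (a 1.0-fold higher number from compound 1 to compound 4 (0.02 log units; within the scatter)) is small. Compound 4 is estimated at 70000 nM with 38000 nM to 120000 nM as the expected range.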

Compound 4, half-maximal cytotoxic concentration: 75000 nM
Beside the measured number, compound 4's estimate is 1.1-fold (0.03 log units) below it; the measured number falls inside the stated range.
By their numbers in this assay, from the lowest: compounds 1, 3, 4 and 2 (each within the scatter of the next).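

Changing the drawn configuration at the saturated ring carbon and the saturated chain carbon together gives a 1.1-fold higher number from compound 1 to compound 4 (0.05 log units; within the scatter) in this assay. Among these compounds, this is the first pair here in which the ring carbon changes, and the result still cannot be told apart from repeat-measurement noise. Configuration at this ring carbon therefore shows no readable effect in this pair.

Going by these compounds, both centres change together, so the contribution of each one alone remains unknown. Also open, on these data alone, is whether this holds when an amine or a carboxylic acid replaces a hydroxyl group.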